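Replacing the Benzyl Group with a Thiazole Amide

The source may hold more compounds than are shown below. What is called first, only, known or untested is meant among the compounds shown, and "the series" means these compounds.

Compound 1 `CCCCNc1nc(N)nc2c1CN(Cc1ccccc1Cl)CC2` carries a 2-chlorobenzyl group on the amine nitrogen of its shared core. Among the measured compounds shown here, in an assay on HEK293 cells for agonist activity at Toll-like receptor 8 (Homo sapiens), read by a luciferase reporter, with a stated time of 6 h (on this read-out lower numbers stand for an effect already at smaller amounts and higher numbers for an effect only at larger amounts of compound), compound 1 gives 0.05 uM and stands second highest of the three numbers measured so far. Compound 2 `CCCCNc1nc(N)nc2c1CN(Cc1cccc(OC)c1Cl)CC2` gives 0.04 uM; the step of a 1.3-fold lower number from compound 1 to compound 2 (0.10 log units; within the scatter) lies within the scatter. Compound 3 `CCCCNc1nc(N)nc2c1CN(Cc1cccc3ccccc13)CC2` gives 0.43 uM, a number beyond the scatter from that of compound 1.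

Compound 4 `CCCCNc1nc(N)nc2c1CN(C(=O)c1scnc1C)CC2` differs from compound 1 in one place: (4-methyl-1,3-thiazol-5-yl)carbonyl in place of 2-chlorobenzyl on an amine nitrogen in a ring. The amine nitrogen thus bears a carbonyl rather than a benzyl carbon, and a five-membered aromatic ring with 2 hetero atoms takes the place of a six-membered aromatic ring of carbon only. For the measured compounds named here, no measured step shares this change. Going by the values given here, the only step, from compound 1 to compound 2, concerns a methoxy on the aromatic ring and is within the scatter, so it says little here. The nearest hint comes from compound 3, where another replacement on the same amine nitrogen gives a higher number. In this assay the number for compound 4 is therefore expected to rise, a 20-fold higher number from compound 1 to compound 4 (1.30 log units; beyond the scatter). The estimate for compound 4 is 1 uM, expected to fall between 0.1 uM and 10 uM.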

Compound 4, minimum effective concentration: 5.6 uM
Estimate against measurement, compound 4: 5.6-fold (0.75 log units) below; the measured number falls inside the stated range.
By their numbers in this assay, from the lowest: compounds 2 and 1 (each within the scatter of the next); then compound 3; then compound 4.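

This step shows that the amine nitrogen in a ring is far less tolerant than the aromatic ring of the benzyl group. In this assay, placing (4-methyl-1,3-thiazol-5-yl)carbonyl on that nitrogen instead of 2-chlorobenzyl gives a 110-fold higher number from compound 1 to compound 4 (2.05 log units; beyond the scatter), whereas adding a methoxy to the aromatic ring gave only a 1.3-fold lower number from compound 1 to compound 2 (0.10 log units; within the scatter). The leaving and entering groups have the same count of heavy atoms, so matching that count does not keep the number low, but the swap changes the ring, the atom attached to the nitrogen and the count of hydrogen-bond acceptors all at once, and nothing measured here explains the rise.

As far as these compounds go, it remains open whether the carbonyl or the five-membered aromatic ring accounts for most of this step. A benzoyl group, which pairs the carbonyl with a six-membered aromatic ring of carbon only, and a (4-methyl-1,3-thiazol-5-yl)methyl group, which pairs the five-membered ring with a plain carbon link, would each change only one of these two features.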